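Trifluoromethyl on the phenyl ring: expected effect in mice

This account rests on a few compounds, and the source may have more. Where it says the series, first, only, none or still open, it means among the compounds named here.

Compound 1 `c1ccc(N2N=NCC2c2ccncc2)cc1`: 165 mg/kg
Compound 2 `COc1ccc(-n2nncc2-c2ccncc2)cc1`: 311 mg/kg
Compound 3 `c1ccc(-n2nncc2-c2ccncc2)cc1`: 78.8 mg/kg

Of the compounds shown here, three have been tested in a functional assay on the whole organism with Mus musculus as the target, in the maximal electroshock model; on this read-out lower numbers stand for an effect already at smaller amounts and higher numbers for an effect only at larger amounts of compound. Compound 3 gives the lowest number of the three, 78.8 mg/kg; the nearest is compound 1 with 165 mg/kg, and compound 2 with 311 mg/kg lies furthest away, both gaps being beyond the usual scatter.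

Compound 4 `FC(F)(F)c1cccc(-n2nncc2-c2ccncc2)c1` differs from compound 3 by a single change: trifluoromethyl in place of hydrogen on an aromatic carbon. Within the data shown here, only one measured step concerns a change of a group on that phenyl ring, the step from compound 2 to compound 3: a 3.9-fold lower number from compound 2 to compound 3 (0.60 log units; beyond the scatter). There, taking a methoxy group off the ring lowered the number. Adding a group back, even a different one in a different position, is therefore more likely to raise the number than to lower it, though the single comparison available makes this uncertain.

Among the measured compounds shown here, for compound 4 a moderate rise is expected, a 1.6-fold higher number from compound 3 to compound 4 (0.22 log units; within the scatter), because the only comparable change, a 3.9-fold lower number from compound 2 to compound 3 (0.60 log units; beyond the scatter), went the other way when a group was removed. The estimate for compound 4 in this assay is 130 mg/kg, with a likely range from 55 mg/kg to 300 mg/kg.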

Compound 4, dose for half-maximal effect: 68.2 mg/kg
Compound 4: the middle estimate sits 1.9-fold (0.28 log units) above what was measured; the measured number falls inside the stated range.
By their numbers in this assay, from the lowest: compounds 4 and 3 (each within the scatter of the next); then compounds 1 and 2 (each within the scatter of the next).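

Trifluoromethyl in place of hydrogen on an aromatic carbon, meta to a large group, gives in this assay a step of a 1.2-fold lower number from compound 3 to compound 4 (0.06 log units; within the scatter) and so leaves compound 3 and compound 4 indistinguishable on this read-out. This position therefore accepts a group of four heavy atoms without a measurable cost, whereas the step of a 3.9-fold lower number from compound 2 to compound 3 (0.60 log units; beyond the scatter) had tied methoxy on the phenyl ring to a higher number, so a group on this ring does not always go with a higher number. No measurement at hand bears on why the number stays within the scatter here.

Compound 2 and compound 4 differ in both the group and its place on the ring, which leaves open whether the contrast between them follows the group or the place, and how methoxy would read at the position that trifluoromethyl holds in compound 4. Also open, going by these compounds, is how an amine, a carboxylic acid or a longer chain at this same position would read in this assay and whether any of them would move the number beyond the scatter.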